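From Nitro to Trifluoromethyl on the Shared Core

A few compounds are considered here, and "the series" means these few. Any claim that something is new, unique, unknown or untested is made for them only; others in the source may bear on it.

Two compounds have numbers in a functional assay on A549 cells (Homo sapiens) for cytotoxicity, read by CCK-8 assay, with a stated time of 24 h; on this read-out higher numbers stand for weaker inhibition and lower numbers for stronger inhibition. Compound 1, `C/C(=C\c1cc(-c2ccc(C#N)cc2)cs1)C(N)=O`, carries a nitrile on its outer ring; in this assay compound 1 gives the limit > 50000 nM, so no number is known for it. Compound 2, `C/C(=C\c1cc(-c2ccc([N+](=O)[O-])cc2)cs1)C(N)=O`, carries a nitro group in that place, and in this assay compound 2 gives 3500 nM, the only actual number shown. The remaining value is the limit of > 50000 nM in this assay, at which 1 of the 2 values shown sits. The step of an at least 14-fold lower number from compound 1 to compound 2 (1.15 log units; beyond the scatter) shows that exchanging this single group moved the read-out well beyond the scatter.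

Compound 3, `C/C(=C\c1cc(-c2ccc(C(F)(F)F)cc2)cs1)C(N)=O`, takes the next step: trifluoromethyl in place of nitro on an aromatic carbon. The measured step bears on it only loosely: it shows that the group at this place can change the number a great deal, yet it says nothing about which way a trifluoromethyl will push it. With no closer comparison available, compound 3 is expected to land between the two measured outcomes, with a 4.3-fold higher number from compound 2 to compound 3 (0.63 log units; beyond the scatter). The estimate for compound 3 is therefore 15000 nM, with a likely range from 3000 nM to 50000 nM.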

Compound 3, half-maximal inhibitory concentration: > 50000 nM
Compound 3: a limit, no number; the forecaster's own chance of this, stated with the estimate: 35%; at least 3.3-fold (0.52 log units) between middle value and limit.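

Replacing nitro with trifluoromethyl gives an at least 14-fold higher number from compound 2 to compound 3 (1.15 log units; beyond the scatter), so the stronger inhibition seen with compound 2 does not extend to this second replacement on the outer ring. Compound 2 now stands alone, since nitro is the only one of the three groups shown at this place that gives an actual number, and no compound here goes against that, as the remaining two values share one limit: the limit of > 50000 nM in this assay, at which 2 of the 3 values shown sit. Compound 1 and compound 3 both end at that limit, so the step between the nitrile and the trifluoromethyl cannot be read, and neither compound can be ranked against the other.

Going by these compounds alone, with only one actual number, it remains open which feature of the nitro group matters here, and whether an amine, a carboxylic acid or a longer chain at this place would also bring a number within reach in this assay. It is also unknown how far the true values of compound 1 and compound 3 lie beyond their shared limit, or whether any other group on the shared core could give a lower number than compound 2 .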